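Extending the Prenyl Chain on a Carbamate Core

This account rests on a few compounds, and the source may have more. Where it says the series, first, only, none or still open, it means among the compounds named here.

Compound 2 `CC(C)=CCC1Cc2c(OC(=O)Nc3ccc(F)cc3)cc(=O)n(CCCO)c2CC1(C)C` was tested in a functional assay on PANC-1 cells (Homo sapiens) for inhibition, read by MTT assay, with a stated time of 24 h, tested at 10 uM (a lower number here means less inhibition, a higher number more inhibition at the concentration tested (going by the name of the read-out)), where compound 2 gives 0%. Compound 1 `COc1ccc(NC(=O)Oc2cc(=O)n(CCCO)c3c2CC(CC=C(C)C)C(C)(C)C3)cc1` gives 0%, and compound 3 `CC(C)=CCC1Cc2c(OC(=O)Nc3ccc(F)cc3F)cc(=O)n(CCCO)c2CC1(C)C` gives 0%, so compound 2 stands level with both: no change at the digits printed from compound 1 to compound 2 (within the scatter), no change at the digits printed from compound 2 to compound 3 (within the scatter), and between the other pair no change at the digits printed from compound 1 to compound 3 (within the scatter). Compound 4 `CC(C)=CCC/C(C)=C/CC1Cc2c(OC(=O)Nc3ccc(F)cc3)cc(=O)n(CCCO)c2CC1(C)C` differs from compound 2 by 3-methylbut-2-en-1-yl in place of hydrogen on a saturated chain carbon bound to a double-bonded chain carbon. Among the compounds with values here, none of the measured steps touches this chain; all three concern the group on the amide-type nitrogen, and none moved beyond the scatter. Within the data shown here, no measured step bears directly on the change. Compound 4 is therefore expected to show a number 2 percentage points higher from compound 2 to compound 4 (within the scatter), nothing beyond the scatter. Compound 4 is estimated at 2%, within a range from 0% to 15%.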

Compound 4, a percentage reported as inhibition, at one concentration (the size of the read-out at that concentration, not a potency): 6.2%
Compound 4: the middle estimate sits 4.2 percentage points below what was measured, and the stated range covers the measured number.
By their numbers in this assay, from the lowest: compounds 1, 2, 3 and 4 (each within the scatter of the next).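

In this assay, within the data shown here, the step of a number 6.2 percentage points higher from compound 2 to compound 4 (within the scatter) is the first look at this chain, and it shows that extending 3-methylbut-2-en-1-yl to 3,7-dimethylocta-2,6-dien-1-yl on the shared core leaves the number within the scatter. So this added stretch of 5 carbon atoms gives no clear gain in inhibition at the concentration tested. Nothing at hand explains this small step. Still open, as far as these compounds go, is whether an amine or a carboxylic acid in place of this chain would move the number beyond the scatter. Also open, from the compounds shown here alone, is whether the longer chain behaves the same with the 4-methoxyphenyl group of compound 1.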